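A few compounds are considered here, and "the series" means these few. Any claim that something is new, unique, unknown or untested is made for them only; others in the source may bear on it.

Compound 1 `COc1ccc(C2=C(c3cc(OC)c(OC)c(OC)c3)C(=O)C(OC(C)=O)C2)cc1`: < 1 ug/mL
Compound 2 `C=CCOc1cc(C2=C(c3cc(OC)c(OC)c(OC)c3)C(=O)C(O)C2)ccc1OC`: > 100 ug/mL
Compound 3 `COc1ccc(C2=C(c3cc(OC)c(OC)c(OC)c3)C(=O)C(O)C2)cc1`: < 1 ug/mL

In an ADME assay on MIA PaCa-2 cells (Homo sapiens) for cytotoxicity, read by MTT assay, with a stated time of 72 h (a higher number here means a weaker inhibitor, a lower number a stronger inhibitor), compound 1 gives < 1 ug/mL, which is a limit of the assay. Compound 2 gives > 100 ug/mL, also a limit. Compound 3 gives < 1 ug/mL, again a limit, so where compound 3 stands is known only as a bound, at the limit of < 1 ug/mL in this assay, at which 2 of the 3 values shown sit. The unmeasured compound 4 `COc1ccc(C2=C(c3cc(OC)c(OC)c(OC)c3)C(=O)C(O)C2)cc1NC(=O)c1ccccc1` differs from compound 3 by benzamido in place of hydrogen on an aromatic carbon. Among the measured compounds shown here, one measured step bears on this place: an at least 100-fold lower number from compound 2 to compound 3 (2.00 log units; beyond the scatter). Read the other way, putting a group onto that aromatic carbon carried the value up to the limit of > 100 ug/mL in this assay, at which 1 of the 3 values shown sits. Benzamido now enters the same place. A large move toward weaker inhibition in this assay is therefore expected, an at least 30-fold higher number from compound 3 to compound 4 (1.47 log units; beyond the scatter). Compound 4 is estimated at 30 ug/mL, between 3 ug/mL and 100 ug/mL.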

Compound 4, half-maximal inhibitory concentration: > 100 ug/mL
Compound 4 was reported as a limit; the forecaster's own chance of this, stated with the estimate: 35%; at least 3.3-fold (0.52 log units) between middle value and limit.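

With benzamido on this aromatic carbon, ortho to a methoxy group, this assay shows an at least 100-fold higher number from compound 3 to compound 4 (2.00 log units; beyond the scatter). Both ends of that step are limits of the assay. Allyloxy is therefore no longer the only group shown at the upper limit: the limit of > 100 ug/mL in this assay, at which 2 of the 4 values shown sit. The step between those two groups cannot be read, so neither can be ranked above the other.

As far as these compounds go, it remains open whether a simple amine or a single fluorine on this carbon would preserve the strong reading of compound 3. From the compounds shown here alone, the true values of compound 3 and compound 4 also remain unknown.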